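A few compounds are considered here, and "the series" means these few. Any claim that something is new, unique, unknown or untested is made for them only; others in the source may bear on it.

Compound 1 `CCO[C@]1(c2ccc(OCc3c(-c4c(Cl)cccc4Cl)noc3C3CC3)cc2Cl)C[C@H](c2cccc(C(=O)O)c2)C1` in an assay on HEK293 cells for agonist activity at Bile acid receptor (Homo sapiens) (on this read-out higher numbers stand for an effect only at larger amounts of compound and lower numbers for an effect already at smaller amounts), gives 220 nM.
Compound 2 `O=C(O)c1cccc([C@H]2C[C@@H]2c2ccc(OCc3c(-c4c(Cl)cccc4Cl)noc3C3CC3)cc2Cl)c1` in this assay gives 90 nM.

Of these two numbers compound 2 holds the lower one, and the value of compound 1 lies above it by more than the usual scatter, so compound 2 stands as the more potent of the pair measured so far. Compound 3 `O=C(O)c1cccc([C@@H]2C[C@H]2c2ccc(OCc3c(-c4c(Cl)cccc4Cl)noc3C3CC3)cc2Cl)c1` is its mirror image: the two compounds have the same atoms and bonds and differ only in configuration as drawn: 2 of 2 stereo elements differ (all stereocentres are inverted: mirror images); a stereocentre at a saturated ring carbon is drawn S in compound 2 and R in compound 3; a stereocentre at a saturated ring carbon is drawn S in compound 2 and R in compound 3. Among the measured compounds shown here, no pair among the measured compounds shows what such a full inversion does in this assay, so the expectation rests on the general observation that mirror images seldom match one another in an assay of this kind, and that one of the two usually sits clearly higher. Compound 3 is therefore expected to give a higher number than compound 2, a step of a 13-fold higher number from compound 2 to compound 3 (1.12 log units; beyond the scatter) upward beyond the scatter, with wide uncertainty. Compound 3 is estimated at 1200 nM, within a range from 150 nM to 10000 nM.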

Compound 3, half-maximal effective concentration: 29 nM
Beside the measured number, compound 3's estimate is 41-fold (1.62 log units) above it; the measured number lies below the stated range.
By their numbers in this assay, from the lowest: compound 3; then compound 2; then compound 1.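

In this assay the inversion of both stereocentres at the saturated ring carbons gives a 3.1-fold lower number from compound 2 to compound 3 (0.49 log units; beyond the scatter) as the first read of what configuration alone does in this set. The assay therefore tells these mirror images apart, with the form drawn R at both centres on the lower side, although the step is only modest. The gap can be assigned to configuration and to nothing else, because no atom or bond changes: the fact that compounds 2 and 3 differ only in the configuration as drawn.

The pair does not show whether inverting the stereocentres of compound 1 would move its number in the same direction or by a similar amount. It also leaves open whether the same preference between mirror images would hold with a tetrazole in place of the carboxylic acid.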